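Amide variation in a small series: from compound 3 to compound 4

The source may report more compounds than this note shows. Statements on the series, on what has been measured and on what is new or still open speak of the compounds shown alone.

Values in a functional assay with Oryctolagus cuniculus as the target (on this read-out lower numbers stand for stronger inhibition and higher numbers for weaker inhibition), so far:
- compound 1 `COc1ccc(-c2nc(CN(C)C)sc2-c2ccc(OC)cc2)cc1` gives 96 nM
- compound 2 `COc1ccc(-c2nc(CNC(C)=O)sc2-c2ccc(OC)cc2)cc1` gives 15 nM
- compound 3 `COc1ccc(-c2nc(CNC(=O)c3cccnc3)sc2-c2ccc(OC)cc2)cc1` gives 25 nM

Compound 3 holds the second highest of the three numbers, and a 3.8-fold lower number from compound 1 to compound 3 (0.58 log units; beyond the scatter) sets it apart from the highest. Compound 4 `COc1ccc(-c2nc(CNC(=O)CSc3ccccc3)sc2-c2ccc(OC)cc2)cc1` differs by (phenylsulfanyl)methyl in place of pyridin-3-yl on a carbonyl carbon with (phenylsulfanyl)methyl in place of pyridin-3-yl on a carbonyl carbon. For the measured compounds named here, the only measured change at that carbon is a 1.7-fold higher number from compound 2 to compound 3 (0.22 log units; within the scatter) and so bears most directly. The a 6.4-fold lower number from compound 1 to compound 2 (0.81 log units; beyond the scatter) replaced dimethylamino and is a different change. No step beyond the scatter is therefore expected in this assay here. The expected step is a 1.2-fold higher number from compound 3 to compound 4 (0.08 log units; within the scatter) in this estimate. For compound 4 the estimated value is 30 nM with a range of 10 nM to 90 nM as expected bounds.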

Compound 4, half-maximal inhibitory concentration: < 100 nM
Compound 4 was reported as a limit (the forecaster's own chance of this, stated with the estimate: 3%); the middle value is on the limit's open side.
By their numbers in this assay, from the lowest: compounds 2 and 3 (each within the scatter of the next); then compound 1.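

In this assay compound 4 gives < 100 nM, which is a limit and not a number. Its steps from compound 1, compound 2 and compound 3 therefore cannot be read. On these data alone, how (phenylsulfanyl)methyl on the carbonyl carbon compares with pyridin-3-yl or methyl in this assay stays open.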